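The compounds below may be only part of what the source reports. "The series", "measured", "known", "first", "only" and "open" are said of these compounds alone.

Of the compounds shown here, three have already been tested in an in vitro functional assay on cells for agonist activity at Bombesin receptor subtype-3 (Homo sapiens), read by luminescence and calcium flux; on this read-out higher numbers stand for an effect only at larger amounts of compound and lower numbers for an effect already at smaller amounts. Compound 1, with the structure `CCCCc1cnc(Cc2ccc(-c3ccccc3C(=O)O)cc2)[nH]1`, gives only a limit in this assay: > 10000 nM. Compound 2, with the structure `CCCCc1cnc(C(CCC)Cc2ccc(-c3ccccc3C(=O)O)cc2)[nH]1`, gives 1180 nM in this assay. Compound 3, with the structure `N#Cc1ccc(Cc2cnc(CCc3ccc(-c4ccccc4C(=O)O)cc3)[nH]2)cc1`, gives 5890 nM in this assay, the highest of the two numbers that were obtained; its nearest neighbour among the numbers is compound 2, whose value is lower by a gap that lies beyond the usual scatter of such measurements.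

Compound 4, with the structure `CC(C)(C)CCc1cnc(CCc2ccc(-c3ccccc3C(=O)O)cc2)[nH]1`, has not yet been measured. It differs from compound 3 in one place: neopentyl in place of 4-cyanophenyl on a saturated chain carbon bound to an aromatic carbon. The aromatic ring carrying the nitrile is thus gone, and in its place stands a short saturated branched chain, while the rest of the shared core is unchanged.

Going by the values given here, no pair of measured compounds mirrors this exact exchange, so the expected outcome rests only on the values gathered so far. Compound 4 is expected to land close to compound 3, with the step of a 1.7-fold lower number from compound 3 to compound 4 (0.23 log units; within the scatter) staying within or only slightly beyond the scatter. The estimated value for compound 4 in this assay is 3500 nM, with a likely range from 900 nM to 14000 nM.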

Compound 4, half-maximal effective concentration: 39 nM
Compound 4: the middle estimate sits 90-fold (1.95 log units) above what was measured; the measured number lies below the stated range.
By their numbers in this assay, from the lowest: compound 4; then compound 2; then compound 3. At a limit, above all of these: compound 1.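

In this assay, putting neopentyl in place of 4-cyanophenyl on a saturated chain carbon bound to an aromatic carbon gives a 150-fold lower number from compound 3 to compound 4 (2.18 log units; beyond the scatter), a large step far beyond the scatter. This is the first pair shown that differs in one place, and it reveals that this position has a strong influence on the read-out: the group at the end of the chain can shift the response substantially while the shared core stays unchanged. The step is read between two real numbers, as the only limit in the set belongs to compound 1: the limit of > 10000 nM in this assay, at which 1 of the 4 values shown sits.

The aromatic ring and the nitrile leave together, while a branched chain with fewer heavy atoms enters, so this single step cannot show whether the loss of the ring, the loss of the nitrile or the arrival of the branched chain accounts for the change. A plain phenyl, a cyclohexyl or an unbranched pentyl chain at the same place would help separate these possibilities.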